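From Methylphenyl to Fluorophenyl on a Shared Core

A few compounds are considered here, and "the series" means these few. Any claim that something is new, unique, unknown or untested is made for them only; others in the source may bear on it.

Compound 1 `CC(C)(C)n1ncc(OCc2nnc(-c3ccccc3)s2)c(Cl)c1=O` in a functional assay on the whole organism for inhibition, with Mythimna separata as the target, with a stated time of 5 days (a higher number here means that more compound is needed for the effect, a lower number that less compound is needed), gives 200000 nM. Compound 2 `Cc1cccc(-c2nnc(COc3cnn(C(C)(C)C)c(=O)c3Cl)s2)c1` in this assay reaches only a limit of the assay, > 299000 nM. Among the measured compounds shown here, the single measured step, an at least 1.4-fold higher number from compound 1 to compound 2 (0.17 log units; that floor lies within the scatter), leaves compound 2 at the limit of > 299000 nM in this assay, at which 1 of the 2 values shown sits. Compound 3 `CC(C)(C)n1ncc(OCc2nnc(-c3ccc(F)cc3)s2)c(Cl)c1=O` differs from compound 2 by 4-fluorophenyl in place of 3-methylphenyl on an aromatic carbon. For the measured compounds named here, only that one step bears on this change, and it stayed within the scatter, so the expected step is an at least 1.1-fold lower number from compound 2 to compound 3 (0.07 log units; that floor lies within the scatter), with no clear direction. Compound 3 is therefore estimated at 250000 nM, between 80000 nM and 600000 nM, and another limit is quite possible.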

Compound 3, half-maximal effective concentration: 21500 nM
Estimate against measurement, compound 3: 12-fold (1.07 log units) above; the whole stated range lies above it.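

Unlike the earlier methyl step, which stayed within the scatter, this position now shows a clear direction: 4-fluorophenyl in place of 3-methylphenyl gives an at least 13-fold lower number from compound 2 to compound 3 (1.14 log units; beyond the scatter), and fluoro in place of hydrogen gives a 9.3-fold lower number from compound 1 to compound 3 (0.97 log units; beyond the scatter). Of the groups shown here, 4-fluorophenyl therefore needs the least compound for the effect. The larger step is only a floor, as compound 2 has a limit of the assay rather than a number: the limit of > 299000 nM in this assay, at which 1 of the 3 values shown sits.

Going by these compounds, whether 3-fluorophenyl, 4-chlorophenyl or 4-methoxyphenyl would give a similar number remains open.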